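The source may report more compounds than this note shows. Statements on the series, on what has been measured and on what is new or still open speak of the compounds shown alone.

Among the measured compounds shown here, compound 2 `Cn1nnnc1SCC(=O)N/N=C/c1ccc(F)cc1` stands highest of the two numbers measured so far in a functional assay on A549 cells (Homo sapiens) for cytotoxicity, read by XTT assay, with a stated time of 24 h (a lower number here means a stronger inhibitor, a higher number a weaker inhibitor), where compound 2 gives 3160000 nM. Its nearest neighbour is compound 1 `Cn1nnnc1SCC(=O)N/N=C/c1ccc([N+](=O)[O-])cc1`, which in this assay gives 632000 nM. For the measured compounds named here, the single step between these two, a 5.0-fold higher number from compound 1 to compound 2 (0.70 log units; beyond the scatter), comes from fluoro in place of nitro on an aromatic carbon of the shared core. Compound 3 `COc1ccc(/C=N/NC(=O)CSc2nnnn2C)cc1` is the next compound, differing from compound 2 by methoxy in place of fluoro on an aromatic carbon. Going by the values given here, no measured step shows what a methoxy group does in this position, so the one step from compound 1 to compound 2 gives only the scale of change a substituent swap on this ring has produced. For compound 3 the expected outcome is a number close to that of compound 2, with the step of a 1.3-fold lower number from compound 2 to compound 3 (0.10 log units; within the scatter) estimated to stay within the scatter, giving an estimate of 2500000 nM with a range from 600000 nM to 10000000 nM.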

Compound 3, half-maximal inhibitory concentration: > 10000000 nM
Compound 3: only a limit was reported (the forecaster's own chance of this, stated with the estimate: 30%); middle value at least 4.0-fold (0.60 log units) from the limit.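

In this assay, compound 3 gives only a limit, > 10000000 nM, rather than an exact number. Methoxy on this aromatic carbon nonetheless has a clear effect: replacing fluoro gives an at least 3.1-fold higher number from compound 2 to compound 3 (0.50 log units; beyond the scatter), and replacing nitro gives an at least 15-fold higher number from compound 1 to compound 3 (1.19 log units; beyond the scatter), so among these three compounds the numbers rise from nitro through fluoro to methoxy, making nitro the strongest inhibitor and methoxy the weakest. Both sizes are minimums, and the true gaps may be wider, as the reading for compound 3 rests on this ceiling: the limit of > 10000000 nM in this assay, at which 1 of the 3 values shown sits.

From the compounds shown here alone, how far compound 3 actually lies beyond its limit remains open. Also open, going by these compounds, is whether this order extends to other groups on the same carbon, such as an amine, a carboxylic acid or a chlorine atom.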